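The source may hold more compounds than are shown below. What is called first, only, known or untested is meant among the compounds shown, and "the series" means these compounds.

Measured in a functional assay on PC-3 cells (Homo sapiens) for cytotoxicity, read by WST assay, with a stated time of 72 h; on this read-out lower numbers stand for stronger inhibition and higher numbers for weaker inhibition:
- Compound 1 `Cc1ccc2c(c1C)NC(=O)C2(c1ccc(O)cc1)C1CCCCCC1`: > 1000 nM (a limit)
- Compound 2 `Cc1ccc2c(c1Cl)NC(=O)C2(c1ccc(O)cc1)C1CCCCCC1`: 17 nM

Compound 1 stands only at a limit of the assay: the limit of > 1000 nM in this assay, at which 1 of the 2 values shown sits. Compound 3 `COc1ccc2c(c1C)NC(=O)C2(c1ccc(O)cc1)C1CCCCCC1` has methoxy in place of methyl on an aromatic carbon, ortho to a methyl group (methoxy in place of methyl on an aromatic carbon). Within the data shown here, the only measured step, chloro in place of methyl, gave an at least 58-fold lower number from compound 1 to compound 2 (1.76 log units; beyond the scatter). It changed the other methyl, which compound 3 keeps, so it bears only loosely on this change. A modest move toward a lower number is therefore expected in this assay, and a result that stays at the limit would be no surprise. The expected step is an at least 2.5-fold lower number from compound 1 to compound 3 (0.39 log units; beyond the scatter). For compound 3 the estimated value is 400 nM, with an expected range of 40 nM to 2000 nM.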

Compound 3, half-maximal inhibitory concentration: 12 nM
For compound 3 the middle estimate is 33-fold (1.52 log units) above the measured one; measured number outside the range, below it.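

Methoxy in place of methyl gives an at least 83-fold lower number from compound 1 to compound 3 (1.92 log units; beyond the scatter) in this assay on an aromatic carbon ortho to a methyl group. Among these compounds, this methyl, and not only the one changed in the earlier step, is therefore a place where a single replacement moves the number strongly. Compound 1 stands at a limit, and the full size of the step cannot be read because the step starts from that limit: the limit of > 1000 nM in this assay, at which 1 of the 3 values shown sits.

The compounds shown leave open whether this gain belongs to methoxy itself or would also come with chloro, an amine or a longer chain such as ethoxy at this carbon.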